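The source may hold more compounds than are shown below. What is called first, only, known or untested is meant among the compounds shown, and "the series" means these compounds.

Compound 1 `O=C(CCCc1cn(Cc2ccc(Cl)cc2)c2ccccc12)NC1CCCCCC1` and compound 2 `O=C(CCCc1cn(Cc2ccccc2)c2ccccc12)NC1CCCCCC1` offer no result to work from in an ADME assay on Vero cells (Chlorocebus sabaeus) for cytotoxicity, read by fluorescence and resazurin assay, with a stated time of 3 days; a lower number here means that less compound is tolerated, a higher number that more compound is tolerated: compound 1 gives "not determined" (no result reported) and compound 2 gives "not determined" (no result reported). Compound 3 `CC(C)(C)c1ccc(S(=O)(=O)n2cc(CCCC(=O)NC3CCCCCC3)c3ccccc32)cc1` reads > 250000 nM in this assay, which is a limit of the assay and not a number. Compound 4 `Cc1cc(S(=O)(=O)n2cc(CCCC(=O)NC3CCCCCC3)c3ccccc32)c(C)cc1Cl` has 4-chloro-2,5-dimethylphenyl in place of 4-(tert-butyl)phenyl on the sulfonyl sulfur (4-chloro-2,5-dimethylphenyl in place of 4-(tert-butyl)phenyl on a sulfonyl sulfur). Within the data shown here, no measured pair shows what such a swap does, so only a small step toward less compound tolerated is expected, and the same limit may well be reached again. The estimated change is an at least 1.3-fold lower number from compound 3 to compound 4 (0.14 log units; that floor lies within the scatter). For compound 4 the estimate is 180000 nM, with an expected range from 60000 nM to 250000 nM.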

Compound 4, half-maximal cytotoxic concentration: > 250000 nM
Compound 4 ended at the assay's limit; the forecaster's own chance of this, stated with the estimate: 60%; middle value at least 1.3-fold (0.14 log units) away from the limit.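

Among these compounds, compound 3 and compound 4 both sit at the same assay limit, so no step between them can be read: the limit of > 250000 nM in this assay, at which 2 of the 4 values shown sit. On these data alone, what 4-chloro-2,5-dimethylphenyl in place of 4-(tert-butyl)phenyl does to the number in this assay stays open.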